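The source may report more compounds than this note shows. Statements on the series, on what has been measured and on what is new or still open speak of the compounds shown alone.

Measured in an ADME assay on BJ cells (Homo sapiens), read by MTT assay, with a stated time of 72 h; on this read-out lower numbers stand for stronger inhibition and higher numbers for weaker inhibition:
- compound 1 `Cc1ncnc2c1c(-c1ccsc1)cn2[C@@H]1O[C@H](CO)[C@@H](O)[C@H]1O`: 96900 nM
- compound 2 `Cc1ncnc2c1c(-c1cc3ccccc3o1)cn2[C@@H]1O[C@H](CO)[C@@H](O)[C@H]1O`: 93900 nM
- compound 3 `C#Cc1cn([C@@H]2O[C@H](CO)[C@@H](O)[C@H]2O)c2ncnc(C)c12`: 50 nM

Among these three, compound 3 has the lowest number, at 50 nM, and it stands well apart from the other two. The next structure, compound 4 `Cc1ncnc2c1c(I)cn2[C@@H]1O[C@H](CO)[C@@H](O)[C@H]1O`, keeps the shared core and changes one group, with iodo in place of ethynyl on an aromatic carbon.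

Going by the values given here, no measured step makes this exact exchange, so the evidence is indirect. Two ring-bearing groups give nearly the same result, with a 1.0-fold lower number from compound 1 to compound 2 (0.01 log units; within the scatter). Replacing either with ethynyl produces a large drop, with a 1900-fold lower number from compound 1 to compound 3 (3.29 log units; beyond the scatter) and a 1900-fold lower number from compound 2 to compound 3 (3.27 log units; beyond the scatter). Like ethynyl, iodo has no ring, so compound 4 is expected to remain much closer to compound 3 than to compound 1 or compound 2. However, ethynyl is the only ringless group measured so far, and its low value may not carry over to iodo. A moderate rise in this assay is therefore expected, with a 6.0-fold higher number from compound 3 to compound 4 (0.78 log units; beyond the scatter). For compound 4 the estimated value is 300 nM, with an expected range from 30 nM to 8000 nM.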

Compound 4, half-maximal inhibitory concentration: > 100000 nM
Compound 4 was reported as a limit (the forecaster's own chance of this, stated with the estimate: 5%); middle value at least 330-fold (2.52 log units) away from the limit.
By their numbers in this assay, from the lowest: compound 3; then compounds 2 and 1 (each within the scatter of the next). At a limit, above all of these: compound 4.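

In this assay compound 4 is reported only as a limit, not as a number: the limit of > 100000 nM in this assay, at which 1 of the 4 values shown sits.

Even so, the change is readable, with an at least 2000-fold higher number from compound 3 to compound 4 (3.30 log units; beyond the scatter), and it shows that the low number of compound 3 does not carry over to every group without a ring at this aromatic carbon. Iodo is also not separated from the two ring-bearing groups, with an at least 1.0-fold higher number from compound 2 to compound 4 (0.02 log units; that floor lies within the scatter) and an at least 1.0-fold higher number from compound 1 to compound 4 (0.01 log units; that floor lies within the scatter), and these floors lie within the scatter and so set no order among compounds 1, 2 and 4. Of the four groups shown at this position, only ethynyl, the one group with a triple bond, gives a low number, and no compound goes against this.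

From the compounds shown here alone, what remains open is whether that low number depends on the triple bond itself or on ethynyl as a whole, a question that a nitrile, a propynyl group or a vinyl group at this carbon could address. Going by these compounds, it is also open how a methyl group, a chloro group or an amine would behave here.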